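Methyl in place of trifluoromethyl: what to expect for toxicity

The source may hold more compounds than are shown below. What is called first, only, known or untested is meant among the compounds shown, and "the series" means these compounds.

Compound 1, `CN1CCN(CCCNCc2cn(-c3ccc([N+](=O)[O-])cc3)nc2-c2ccc(Cl)cc2)CC1`, in an ADME assay on Huh-7 cells (Homo sapiens) for cytotoxicity (a higher number here means that more compound is tolerated, a lower number that less compound is tolerated), gives 3700 nM.
Compound 2, `CN1CCN(CCNCc2cn(-c3ccc([N+](=O)[O-])cc3)nc2-c2ccc(OC(F)(F)F)cc2)CC1`, in this assay gives 4400 nM.
Compound 3, `CN1CCN(CCNCc2cn(-c3ccc(F)cc3F)nc2-c2ccc(OC(F)(F)F)cc2)CC1`, in this assay gives 18000 nM.

Compound 3 stands highest of the three, that is, it is the best tolerated: its nearest neighbour is compound 2, and compound 1 lies furthest away, both gaps beyond the scatter. Among the measured compounds shown here, the only single-point step measured here is a 4.1-fold higher number from compound 2 to compound 3 (0.61 log units; beyond the scatter), and it concerns a group on an aromatic nitrogen, not the place that changes now.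

Compound 4 is `COc1ccc(-c2nn(-c3ccc(F)cc3F)cc2CNCCN2CCN(C)CC2)cc1`. It differs from compound 3 in this way: methyl in place of trifluoromethyl on an oxygen on an aromatic ring. For the measured compounds named here, no measured pair isolates this change; compound 1 and compound 2 differ at the same aromatic position but also elsewhere, and their values lie within the scatter of each other. Going by the values given here, with no step that bears on the change, the expectation is one of no step beyond the scatter: a 1.2-fold lower number from compound 3 to compound 4 (0.08 log units; within the scatter). Compound 4 is therefore expected to give 15000 nM, with a range from 6000 nM to 40000 nM.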

Compound 4, half-maximal cytotoxic concentration: > 20000 nM
Compound 4: only a limit was reported; the forecaster's own chance of this, stated with the estimate: 10%; middle value at least 1.3-fold (0.12 log units) away from the limit.
By their numbers in this assay, from the lowest: compounds 1 and 2 (each within the scatter of the next); then compound 3. At a limit, above all of these: compound 4.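

Trifluoromethoxy to methoxy is the first change at this position that can be read on its own, with the rest of compound 3 held fixed. In this assay compound 4 is reported only as a limit, > 20000 nM. The data give an at least 1.1-fold higher number from compound 3 to compound 4 (0.04 log units; that floor lies within the scatter), so swapping trifluoromethyl for methyl on this oxygen brings no loss in tolerated concentration, but the true size of the gain cannot be read from a value set at the edge of the assay: the limit of > 20000 nM in this assay, at which 1 of the 4 values shown sits.

The compounds shown leave open how a longer chain on this oxygen, such as ethyl or propyl, or a free hydroxyl in place of the whole group, would behave. As far as these compounds go, whether the same change would hold with 4-nitrophenyl on the aromatic nitrogen also stays open.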